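Adding a second bromo to compound 3

The compounds below may be only part of what the source reports. "The series", "measured", "known", "first", "only" and "open" are said of these compounds alone.

Measured in a functional assay on A549 cells (Homo sapiens) for cytotoxicity, read by MTT assay, with a stated time of 72 h; on this read-out lower numbers stand for stronger inhibition and higher numbers for weaker inhibition:
Compound 1 `O=C(N/N=C/c1cccc(Br)c1)Nc1cc2c(Nc3ccc(F)c(Cl)c3)ncnc2cc1O[C@H]1CCOC1`: 10700 nM
Compound 2 `O=C(N/N=C/c1ccc(F)cc1Cl)Nc1cc2c(Nc3ccc(F)c(Cl)c3)ncnc2cc1O[C@H]1CCOC1`: 27200 nM
Compound 3 `O=C(N/N=C/c1ccc(O)c(Br)c1)Nc1cc2c(Nc3ccc(F)c(Cl)c3)ncnc2cc1O[C@H]1CCOC1`: 4310 nM

Of these three, compound 3 has the lowest number, 4310 nM. Hydroxy in place of hydrogen gave a 2.5-fold lower number from compound 1 to compound 3 (0.39 log units; beyond the scatter). Exchanging the whole aryl group gave a 6.3-fold lower number from compound 2 to compound 3 (0.80 log units; beyond the scatter), while the other exchange gave a 2.5-fold higher number from compound 1 to compound 2 (0.41 log units; beyond the scatter). Compound 4 `O=C(N/N=C/c1cc(Br)c(O)c(Br)c1)Nc1cc2c(Nc3ccc(F)c(Cl)c3)ncnc2cc1O[C@H]1CCOC1` differs from compound 3 by bromo in place of hydrogen on an aromatic carbon, ortho to a hydroxy group, which turns 3-bromo-4-hydroxyphenyl into 3,5-dibromo-4-hydroxyphenyl. Going by the values given here, no measured step isolates this change. Among the compounds with values here, the nearest guide is the one step that adds a single group to this aromatic ring, a 2.5-fold lower number from compound 1 to compound 3 (0.39 log units; beyond the scatter), and it was modest. Only a small move towards a lower number is therefore expected, and the estimated step is a 1.4-fold lower number from compound 3 to compound 4 (0.16 log units; within the scatter). The expected value for compound 4 is 3000 nM, with an estimated range of 1000 nM to 9000 nM.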

Compound 4, half-maximal inhibitory concentration: 8910 nM
Compound 4: the middle estimate sits 3.0-fold (0.47 log units) below what was measured, within the range that was stated.
By their numbers in this assay, from the lowest: compound 3; then compounds 4 and 1 (each within the scatter of the next); then compound 2.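

In this assay, adding the second bromo, ortho to a hydroxy group, ran against the earlier hydroxy step on this ring: it gave a 2.1-fold higher number from compound 3 to compound 4 (0.32 log units; beyond the scatter) and the hydroxy had given a 2.5-fold lower number from compound 1 to compound 3 (0.39 log units; beyond the scatter). The gain held by compound 3 therefore did not extend to 3,5-dibromo-4-hydroxyphenyl, and a 1.2-fold lower number from compound 1 to compound 4 (0.08 log units; within the scatter) leaves compound 4 within the scatter of compound 1, while a 3.1-fold lower number from compound 2 to compound 4 (0.48 log units; beyond the scatter) shows that this aryl group still separates from 2-chloro-4-fluorophenyl. No measurement available here explains why the added bromo raised the number.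

The compounds shown leave open whether chloro, methyl or methoxy at this same position would shift the number as bromo did. They also leave open how a 3,5-dibromophenyl group, with hydrogen in place of the hydroxy, would compare with compound 4.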